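Halogen and methoxy swaps on the thiourea aryl ring

This account rests on a few compounds, and the source may have more. Where it says the series, first, only, none or still open, it means among the compounds named here.

Three members of the series have numbers in a functional assay on MKN-74 cells (Homo sapiens) for antiproliferative activity, with a stated time of 24 h; a lower number here means a stronger inhibitor, a higher number a weaker inhibitor. Compound 1 `NC(=O)c1c(NC(=O)c2ccccc2Cl)sc2c1CCN(C(=S)Nc1ccccc1Br)C2` gives 10800 nM. Compound 2 `NC(=O)c1c(NC(=O)c2ccccc2I)sc2c1CCN(C(=S)Nc1ccccc1Cl)C2` gives 17500 nM. Compound 3 `NC(=O)c1c(NC(=O)c2ccccc2I)sc2c1CCN(C(=S)Nc1ccccc1Br)C2` gives 22400 nM, the highest number of the three; its nearest neighbour is compound 2, and the difference between the two lies within the scatter, while the distance to compound 1 goes beyond it. The two measured steps into compound 3 are a 2.1-fold higher number from compound 1 to compound 3 (0.32 log units; beyond the scatter) and a 1.3-fold higher number from compound 2 to compound 3 (0.11 log units; within the scatter).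

Compound 4 `COc1ccccc1NC(=S)N1CCc2c(sc(NC(=O)c3ccccc3I)c2C(N)=O)C1` differs from compound 3 by one change: methoxy in place of bromo on an aromatic carbon. Among the compounds with values here, of the measured steps, only the one from compound 2 to compound 3 touches the same aryl ring on the thiourea side, and that halogen swap stayed within the scatter. Within the data shown here, no measured step covers a methoxy at this position, so the direction of any effect is unknown from the series itself. On that basis no step beyond the scatter is expected in this assay, and the step from compound 3 to compound 4 is estimated at a 1.1-fold lower number from compound 3 to compound 4 (0.05 log units; within the scatter). Compound 4 is therefore expected to give 20000 nM, with a range from 8000 nM to 50000 nM.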

Compound 4, half-maximal inhibitory concentration: 41800 nM
Compound 4: the middle estimate sits 2.1-fold (0.32 log units) below what was measured; the range from low to high includes it.
By their numbers in this assay, from the lowest: compounds 1, 2, 3 and 4 (each within the scatter of the next, the first and the last beyond it).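

In this assay, within the data shown here, the methoxy group gives the first step on the thiourea aryl ring that goes beyond the scatter: a 2.4-fold higher number from compound 2 to compound 4 (0.38 log units; beyond the scatter) is modest and replaces chloro with methoxy. The matching replacement of bromo stays within the scatter at a 1.9-fold higher number from compound 3 to compound 4 (0.27 log units; within the scatter) and the swap between the two halogens also stays within it at a 1.3-fold higher number from compound 2 to compound 3 (0.11 log units; within the scatter), so this aromatic carbon, ortho to a large group, shows only a small response to leaving the halogens, and whether that response can be read at all depends on which halogen is the reference. No measurement in hand bears on why the 2-methoxyphenyl compound behaves this way.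

Still open, going by these compounds, is whether a group of another kind at this position, such as an amine, a carboxylic acid or a longer chain such as ethoxy, would give a larger step in either direction. Also open, on these data alone, is whether the methoxy step holds when chloro rather than iodo sits on the other aryl ring, the combination that compound 1 carries with bromo on the thiourea side.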